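From a 2-chlorophenyl amide to a 3-fluorobenzyl amide

The source may report more compounds than this note shows. Statements on the series, on what has been measured and on what is new or still open speak of the compounds shown alone.

Three amides on a shared core have been tested in a functional assay (QGY7701 cells, Homo sapiens) for inhibition, read by MTT assay, with a stated time of 48 h; on this read-out higher numbers stand for weaker inhibition and lower numbers for stronger inhibition: compound 1 (`COc1ccc2c(=O)c(/C=C/C(=O)Nc3cccc(C)c3)coc2c1`), compound 2 (`COc1ccc2c(=O)c(/C=C/C(=O)Nc3cccc(Cl)c3)coc2c1`) and compound 3 (`COc1ccc2c(=O)c(/C=C/C(=O)Nc3ccccc3Cl)coc2c1`). Compound 1 reads > 100000 nM, which is a limit of the assay and not a number. Compound 2 reads > 100000 nM, which is also a limit. Among the measured compounds shown here, compound 3 gives 23000 nM, the only true number among the three. The evidence is therefore thin: the limit of > 100000 nM in this assay, at which 2 of the 3 values shown sit.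

The next compound, compound 4 (`COc1ccc2c(=O)c(/C=C/C(=O)NCc3cccc(F)c3)coc2c1`), carries 3-fluorobenzyl in place of 2-chlorophenyl on an amide-type nitrogen.

For the measured compounds named here, two measured steps bear on this change: an at least 4.3-fold lower number from compound 1 to compound 3 (0.63 log units; beyond the scatter), and an at least 4.3-fold lower number from compound 2 to compound 3 (0.63 log units; beyond the scatter). Both lie beyond the scatter, and both show that replacing the 2-chlorophenyl group has so far cost measurable inhibition. A third step, a step that the two limits leave unreadable from compound 1 to compound 2, adds nothing. No benzyl group has been measured yet, so this reasoning is only a rough guide. Compound 4 gives up the group found in compound 3, so weaker inhibition is expected, and a reading at the limit would be no surprise. The expected change is a 2.0-fold higher number from compound 3 to compound 4 (0.29 log units; within the scatter). For compound 4 the estimated value is 45000 nM, with an expected range of 14000 nM to 100000 nM.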

Compound 4, half-maximal inhibitory concentration: 28600 nM
Beside the measured number, compound 4's estimate is 1.6-fold (0.20 log units) above it, and the stated range covers the measured number.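

In this assay, compound 4 shows that a benzyl group can stand on this amide-type nitrogen and still give a true number, and the step from the 2-chlorophenyl amide is a 1.2-fold higher number from compound 3 to compound 4 (0.09 log units; within the scatter), so the two groups cannot be told apart here. Measurable inhibition on this shared core is therefore no longer tied to the 2-chlorophenyl group alone, as it seemed to be with compound 3 as the only true number. The 3-fluorobenzyl group also stands clear of the other two amides, with an at least 3.4-fold lower number from compound 2 to compound 4 (0.54 log units; beyond the scatter) and an at least 3.4-fold lower number from compound 1 to compound 4 (0.54 log units; beyond the scatter), although each of these steps gives only a minimum size, not a full one: the limit of > 100000 nM in this assay, at which 2 of the 4 values shown sit.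

Compound 4 differs from the other amides both in the benzyl link to the ring and in the fluorine on it, so the compounds shown cannot say which of the two matters. Going by these compounds, how a plain benzyl group, a 2-chlorobenzyl group or a longer chain such as 2-phenylethyl would read on this nitrogen also stays open.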